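Swapping one cyclohexyl for benzyl in a bis-benzimidazole core

A few compounds are considered here, and "the series" means these few. Any claim that something is new, unique, unknown or untested is made for them only; others in the source may bear on it.

Among the compounds with values here, compound 3 `c1cn2cc(-c3ccc4c(c3)ncn4C3CCCCC3)nc(-c3ccc4ncn(C5CCCCC5)c4c3)c2n1` gives the highest of the three numbers so far in a functional assay on SF-295 cells (Homo sapiens) for inhibition, read by sulforhodamine B assay, with a stated time of 48 h, tested at 10 uM (a higher number here means more inhibition at the concentration tested (going by the name of the read-out), a lower number less inhibition), at 50.6%. Within the data shown here, compound 1 `Cc1cccc(-c2cn3ccnc3c(-c3ccc4ncn(Cc5ccccc5)c4c3)n2)c1` gives 14.3% and compound 2 `c1ccc(Cn2cnc3ccc(-c4nc(-c5cccc6ccccc56)cn5ccnc45)cc32)cc1` gives 8.22% in this assay; the only measured step between them, a number 6.1 percentage points lower from compound 1 to compound 2 (within the scatter), concerns an aromatic carbon and does not touch the ring nitrogen changed here. Compound 4 `c1ccc(Cn2cnc3ccc(-c4nc(-c5ccc6c(c5)ncn6C5CCCCC5)cn5ccnc45)cc32)cc1` differs from compound 3 by benzyl in place of cyclohexyl on an aromatic nitrogen. Among the measured compounds shown here, no measured step tests this exact change, but the two compounds bearing benzyl on that nitrogen, compound 1 and compound 2, both sit far below compound 3, so a drop beyond the scatter is expected, though compound 4 keeps one cyclohexyl. The expected step is a number 20.6 percentage points lower from compound 3 to compound 4 (beyond the scatter). Compound 4 is estimated at 30%, between 10% and 52%.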

Compound 4, a percentage reported as inhibition, at one concentration (the size of the read-out at that concentration, not a potency): -81.4%
For compound 4 the middle estimate is 111.4 percentage points above the measured one, outside the stated range (below it).
By their numbers in this assay, from the lowest: compound 4; then compounds 2 and 1 (each within the scatter of the next); then compound 3.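

On this aromatic nitrogen, the swap of cyclohexyl for benzyl is far from a mild change: the reading falls by a number 132 percentage points lower from compound 3 to compound 4 (beyond the scatter) even though the other cyclohexyl stays in place. In this assay compound 4 gives -81.4% as its reading, so the number does not merely shrink towards zero but passes below it. Nothing measured here explains this drop.

A single pair cannot separate the effect of the aromatic ring in benzyl from that of its extra carbon. Going by these compounds, whether methyl, a longer alkyl chain or a chain ending in an amine on this nitrogen would keep the reading of compound 3 remains open.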